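Changing the Ester of Compound 1 to an Aminoethyl Amide

The source may report more compounds than this note shows. Statements on the series, on what has been measured and on what is new or still open speak of the compounds shown alone.

Measured compounds:
compound 1, `COC(=O)c1c(O)c2ccccc2n(C)c1=O`, 18.4%
compound 2, `COC(=O)c1c(O)c2ccccc2n(-c2ccccc2)c1=O`, 19.3%

In a functional assay, with a stated time of 60 min, tested at 0.5 mM (on this read-out higher numbers stand for a stronger effect at the one concentration tested and lower numbers for a weaker effect), compound 1 gives 18.4%, the lowest of the two numbers measured; compound 2 gives 19.3%, and the two lie within the usual scatter of each other, so no order between them can be claimed. Among the measured compounds shown here, the one measured step, a number 0.9 percentage points higher from compound 1 to compound 2 (within the scatter), concerns a change on the aromatic nitrogen of the shared core and stays within the scatter.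

Compound 3, `Cn1c(=O)c(C(=O)NCCN)c(O)c2ccccc21`, has not yet been measured. It differs from compound 1 at a different place: (2-aminoethyl)amino in place of methoxy on a carbonyl carbon

For the measured compounds named here, no measured step touches the carbonyl carbon, so the only guidance is that compound 1 and compound 2 both sit near the same level and that the one recorded change left this read-out unmoved. For compound 3 the step of a number 1.6 percentage points higher from compound 1 to compound 3 (within the scatter) is expected to stay within the scatter, in no clear direction. Compound 3 is therefore estimated at 20%, with a range from 5% to 40%.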

Compound 3, a percentage reported as activity, at one concentration (the size of the read-out at that concentration, not a potency): 37.1%
Compound 3: the middle estimate sits 17.1 percentage points below what was measured, and the stated range covers the measured number.
By their numbers in this assay, from the lowest: compounds 1 and 2 (each within the scatter of the next); then compound 3.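

In this assay, the carbonyl carbon is a place where the read-out can move: putting (2-aminoethyl)amino in place of methoxy gives a number 18.7 percentage points higher from compound 1 to compound 3 (beyond the scatter), whereas the earlier step on the aromatic nitrogen, a number 0.9 percentage points higher from compound 1 to compound 2 (within the scatter), showed no such movement. This single change does several things at once, turning methoxycarbonyl into (2-aminoethyl)carbamoyl, so the ester becomes an amide and the new group also carries a chain that ends in an amine, and one pair of compounds cannot separate these parts. Nothing available here explains the higher number.

Still open, as far as these compounds go, is whether the amide link or the end amine goes with the rise, which a plain ethyl amide, with no amine at the end of its chain, would help to separate, while a longer chain such as 3-aminopropyl or a carboxylic acid at the same carbonyl carbon would show how much this position tolerates. From the compounds shown here alone, it is also open whether the same (2-aminoethyl)carbamoyl group would give a similar step alongside the phenyl on the nitrogen of compound 2, and since each number comes from one concentration, none of them gives a potency.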